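The source may hold more compounds than are shown below. What is called first, only, known or untested is meant among the compounds shown, and "the series" means these compounds.

Three compounds built on one shared core are compared in a functional assay on HL-60 cells (Homo sapiens) for cytotoxicity, read by WST assay, with a stated time of 48 h; a lower number here means a stronger inhibitor, a higher number a weaker inhibitor. Compound 1 `CCCCC[C@H](C(C)C)C(c1ccc(O)c(OC)c1)c1ccc(O)c(OC)c1` gives 9600 nM, compound 2 `COc1cc(C(c2ccc(O)c(OC)c2)[C@H](C)[C@@H](C)CF)ccc1O` gives 45000 nM, and compound 3 `COC[C@@H](C)[C@H](C)C(c1ccc(O)c(OC)c1)c1ccc(O)c(OC)c1` gives 73000 nM. Compound 3 thus carries the highest number of the three, meaning the weakest inhibition: its gap to compound 2 lies within the scatter, while the step of a 7.6-fold higher number from compound 1 to compound 3 (0.88 log units; beyond the scatter) lies beyond it. The unmeasured compound 4 `COc1cc(C(c2ccc(O)c(OC)c2)[C@@H](C)[C@@H](C)CO)ccc1O` differs from compound 3 in a single place: 1-(hydroxymethyl)ethyl in place of 1-(methoxymethyl)ethyl on a saturated chain carbon bound to two saturated chain carbons. Within the data shown here, no measured pair exchanges a 1-(methoxymethyl)ethyl for a 1-(hydroxymethyl)ethyl, so nothing speaks directly to this change. The two steps that replaced the 1-isopropylhexyl chain with a shorter group, a 4.7-fold higher number from compound 1 to compound 2 (0.67 log units; beyond the scatter) and a 7.6-fold higher number from compound 1 to compound 3 (0.88 log units; beyond the scatter), both moved the number modestly upward, and the exchange a 1.6-fold higher number from compound 2 to compound 3 (0.21 log units; within the scatter) stayed within the scatter. Treating the 1-(hydroxymethyl)ethyl as one more small variant of the same kind, a step of a 1.2-fold higher number from compound 3 to compound 4 (0.07 log units; within the scatter) in this assay is expected, hardly beyond the scatter. Compound 4 is therefore estimated at 85000 nM, with a likely range from 30000 nM to 220000 nM.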

Compound 4, half-maximal inhibitory concentration: > 100000 nM
Compound 4: no number, only a limit; the forecaster's own chance of this, stated with the estimate: 15%; middle value at least 1.1-fold (0.07 log units) from the limit.
By their numbers in this assay, from the lowest: compound 1; then compounds 2 and 3 (each within the scatter of the next). At a limit, above all of these: compound 4.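

In this assay, compound 4 gives no number, only a limit of the assay: the limit of > 100000 nM in this assay, at which 1 of the 4 values shown sits. Among these compounds, the exchange at this place, 1-(hydroxymethyl)ethyl in place of 1-(methoxymethyl)ethyl, adds a hydrogen-bond donor that the leaving group lacks, and an at least 1.3-fold higher number from compound 3 to compound 4 (0.13 log units; that floor lies within the scatter) gives only a floor, so this change can be called neither a real loss nor no change, though the earlier compounds offered no reading of it at all. Among the compounds shown here, the other two steps say more: an at least 2.2-fold higher number from compound 2 to compound 4 (0.34 log units; beyond the scatter) shows a floor already beyond the scatter, and an at least 10-fold higher number from compound 1 to compound 4 (1.01 log units; beyond the scatter) is the first step in this small set to count as large, whereas the earlier steps from compound 1 were modest.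

As far as these compounds go, how far the true value of compound 4 lies past its limit remains unknown, and with it the real size of all three steps. Also open, from the compounds shown here alone, is whether an amine or a carboxylic acid at the end of this short chain would bring a readable number back, and whether a hydroxymethyl group on a longer chain, such as the 1-isopropylhexyl of compound 1, would behave in the same way.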